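This account rests on a few compounds, and the source may have more. Where it says the series, first, only, none or still open, it means among the compounds named here.

Going by the values given here, in a functional assay on K562/Adr cells (Homo sapiens) for cytotoxicity, read by sulforhodamine B assay, with a stated time of 48 h (a lower number here means a stronger inhibitor, a higher number a weaker inhibitor), compound 2 `CCN(CC)CCCn1c(=O)/c(=C/c2ccccc2O)s/c1=C1\C(=O)Nc2ccc(C)cc21` gives 30600 nM, the highest number of the three measured so far. Compound 1 `CCN(CC)CCCn1c(=O)/c(=C/c2cc(OC)c(OC)c(OC)c2)s/c1=C1/C(=O)Nc2ccc(C)cc21` gives 2020 nM, and compound 3 `CCN(CC)CCCn1c(=O)/c(=C/c2cc(OC)c(OC)c(OC)c2)s/c1=C1\C(=O)Nc2ccc(C)cc21` gives 2020 nM. Compound 4 `CCN(CC)CCCn1c(=O)/c(=C/c2ccccc2O)s/c1=C1/C(=O)Nc2ccc(C)cc21` is the next to be measured, and its difference from compound 2 is the two compounds have the same atoms and bonds and differ only in configuration as drawn: 1 of 2 stereo elements differ; a double bond is drawn Z in compound 2 and E in compound 4. Among the compounds with values here, the closest precedent is no change at the digits printed from compound 1 to compound 3 (within the scatter), where a double bond is drawn E in compound 1 and Z in compound 3. The much larger a 15-fold lower number from compound 2 to compound 3 (1.18 log units; beyond the scatter) comes from replacing 2-hydroxyphenyl with 3,4,5-trimethoxyphenyl, a swap that plays no part here. So no step beyond the scatter is expected in this assay. The step expected is no change at the digits printed from compound 2 to compound 4 (within the scatter). Compound 4 is estimated at 30600 nM, with an expected range from 15000 nM to 60000 nM.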

Compound 4, half-maximal inhibitory concentration: 30600 nM
Compound 4: the middle estimate sits on the measured number at the digits printed; the range from low to high includes it.
By their numbers in this assay, from the lowest: compounds 1 and 3 (each within the scatter of the next); then compounds 2 and 4 (each within the scatter of the next).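

In this assay, the double bond's drawn configuration now gives no change at the digits printed from compound 2 to compound 4 (within the scatter), so the result seen with 3,4,5-trimethoxyphenyl also holds with 2-hydroxyphenyl. The aryl change is also large when read across the two configurations, with a 15-fold higher number from compound 1 to compound 4 (1.18 log units; beyond the scatter). Its size does not depend on the configuration drawn: the same change on two cores in this assay, a 15-fold lower number (1.18 log units; beyond the scatter) from compound 2 to compound 3 and a 15-fold lower number (1.18 log units; beyond the scatter) from compound 4 to compound 1, 1.0-fold (0.00 log units) apart, within the scatter of two such steps

On these data alone, whether a phenyl ring carrying an amine or a carboxylic acid would give a number nearer compound 2 or compound 3 remains open. The matching digits also cannot show whether each drawn pair was tested as two separate forms.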